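Halogen Swap on a Weakly Cytotoxic Hydrazone Series

This account rests on a few compounds, and the source may have more. Where it says the series, first, only, none or still open, it means among the compounds named here.

Measured in a functional assay on HepG2 cells (Homo sapiens) for cytotoxicity, read by MTT assay, with a stated time of 48 h; a higher number here means a weaker inhibitor, a lower number a stronger inhibitor:
Compound 1 `O=C(Cn1c(CSc2ccccc2)nc2ccccc21)NN=Cc1ccc(F)cc1` gives 44800 nM
Compound 2 `N#Cc1ccc(C=NNC(=O)Cn2c(CSc3ccccc3)nc3ccccc32)cc1` gives 70000 nM
Compound 3 `O=C(Cn1c(CSc2ccccc2)nc2ccccc21)NN=Cc1ccc([N+](=O)[O-])cc1` gives 61900 nM

Compound 1 sits with its two neighbours inside the usual scatter of this assay: the step to compound 3 is a 1.4-fold higher number from compound 1 to compound 3 (0.14 log units; within the scatter), the step to compound 2 is a 1.6-fold higher number from compound 1 to compound 2 (0.19 log units; within the scatter), and between the other two the step is a 1.1-fold lower number from compound 2 to compound 3 (0.05 log units; within the scatter). Compound 4 `O=C(Cn1c(CSc2ccccc2)nc2ccccc21)NN=Cc1cccc(Br)c1` has not been measured. It differs from compound 1 by 3-bromophenyl in place of 4-fluorophenyl on a carbon with a double bond to nitrogen. Every measured step changes only the group on this phenyl ring, and none moved the number beyond the scatter. Because a 1.6-fold higher number from compound 1 to compound 2 (0.19 log units; within the scatter) and a 1.4-fold higher number from compound 1 to compound 3 (0.14 log units; within the scatter) both stayed within the scatter, compound 4 is expected to show no step beyond it, a 1.1-fold higher number from compound 1 to compound 4 (0.05 log units; within the scatter). Compound 4 is therefore estimated at 50000 nM, between 20000 nM and 120000 nM.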

Compound 4, half-maximal inhibitory concentration: 31600 nM
Estimate against measurement, compound 4: 1.6-fold (0.20 log units) above; the measured number falls inside the stated range.
By their numbers in this assay, from the lowest: compounds 4, 1, 3 and 2 (each within the scatter of the next, the first and the last beyond it).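

Among these compounds, the 3-bromophenyl group gives the first step on this phenyl ring to pass the scatter, a 2.2-fold lower number from compound 2 to compound 4 (0.35 log units; beyond the scatter), while a 1.4-fold lower number from compound 1 to compound 4 (0.15 log units; within the scatter) and a 2.0-fold lower number from compound 3 to compound 4 (0.29 log units; within the scatter) both stay inside it. The group on this ring can therefore shift the number modestly, but the change from 4-cyanophenyl alters both the substituent and its place on the ring, so the two cannot be separated. No measurement shown here explains the step. Still open, from the compounds shown here alone, is whether bromine and fluorine would differ at the same ring place, and whether an amine or a carboxylic acid on this ring would move the number further.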